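Fluorine Added to the Aniline Ring of Compound 2

The source may report more compounds than this note shows. Statements on the series, on what has been measured and on what is new or still open speak of the compounds shown alone.

Of the compounds shown here, two sharing the same amide-linked core have been measured. In a functional assay on A549 cells (Homo sapiens) for antiproliferative activity, read by MTT assay, with a stated time of 72 h (on this read-out lower numbers stand for stronger inhibition and higher numbers for weaker inhibition), compound 1 `O=C(Nc1ccc(Oc2ccnc3[nH]ccc23)c(F)c1)c1cc2cccnc2n(-c2ccccc2)c1=O` gives 190 nM. Compound 2 `Cn1ccc2c(Oc3ccc(NC(=O)c4cc5cccnc5n(-c5ccccc5)c4=O)cc3)ccnc21` differs in the methylated bicyclic ether part and in the absence of fluorine; in this assay compound 2 gives 850 nM, the highest of the two numbers, and the gap to compound 1 lies beyond the usual scatter. Compound 3 `Cn1ccc2c(Oc3ccc(NC(=O)c4cc5cccnc5n(-c5ccccc5)c4=O)cc3F)ccnc21` keeps the whole of compound 2 and adds one atom: fluoro in place of hydrogen on an aromatic carbon. Among the compounds with values here, no measured pair isolates this change, so its size is not known from the data. Compound 1 also carries a fluorine on the same ring and gives the lower number, which is the only hint available. Compound 3 is therefore expected to give a somewhat lower number than compound 2, a step of a 1.7-fold lower number from compound 2 to compound 3 (0.23 log units; within the scatter), with wide uncertainty. The estimate for compound 3 in this assay is 500 nM, within 200 nM to 1500 nM.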

Compound 3, half-maximal inhibitory concentration: 430 nM
Estimate against measurement, compound 3: 1.2-fold (0.07 log units) above, within the range that was stated.
By their numbers in this assay, from the lowest: compound 1; then compounds 3 and 2 (each within the scatter of the next).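

In this assay, fluoro in place of hydrogen on an aromatic carbon, ortho to a large group and meta to a large group, can now be read on its own, and it gives a 2.0-fold lower number from compound 2 to compound 3 (0.30 log units; within the scatter), so this single atom brings no change that stands clear of the scatter. The gap between compound 1 and compound 2 had spanned two changes at once; with fluoro present in both compounds, methyl in place of hydrogen on an aromatic nitrogen gives a 2.3-fold higher number from compound 1 to compound 3 (0.35 log units; beyond the scatter), a step that does lie beyond the scatter. Nothing shown here bears on why either step has the size it has.

The compounds shown leave open how chloro or a nitrile would read on that same aromatic carbon. They also leave open how ethyl or a longer chain would read on the aromatic nitrogen.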